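Replacing a Hydroxypropoxy Chain with a Bromobenzyloxy Group

The compounds below may be only part of what the source reports. "The series", "measured", "known", "first", "only" and "open" are said of these compounds alone.

Measured so far, in a functional assay on a cell-free system (plasma, Oryctolagus cuniculus) for inhibition, with stated times of 5 min, 1 min and 6 min; on this read-out lower numbers stand for stronger inhibition and higher numbers for weaker inhibition:
- compound 1 `CCOC(=O)c1c(C)nc(-c2ccccc2C#N)n1OC` gives 14900 nM
- compound 2 `CCOC(=O)c1c(C)nc(-c2ccccc2)n1OC` gives only a limit of the assay, > 30000 nM
- compound 3 `CCOC(=O)c1c(C)nc(-c2cccc(C#N)c2)n1OCCCO` gives 11400 nM

Compound 3 has the lowest of the two numbers shown, but its nearest neighbour, compound 1, sits within the usual scatter, so the two cannot be ranked. Among the measured compounds shown here, the one measured step, an at least 2.0-fold higher number from compound 1 to compound 2 (0.30 log units; that floor lies within the scatter), concerns a nitrile and touches the limit noted in the limit of > 30000 nM in this assay, at which 1 of the 3 values shown sits.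

Compound 4 `CCOC(=O)c1c(C)nc(-c2cccc(C#N)c2)n1OCc1ccc(Br)cc1` differs from compound 3 in one place: 4-bromophenyl in place of 2-hydroxyethyl on a saturated chain carbon bound to an oxygen on an aromatic ring. For the measured compounds named here, no measured step bears on this change; the only step known concerns a different group on the aromatic ring, and nothing is known about changes on the chain bound to the oxygen. The expectation for compound 4 is therefore anchored on compound 3 alone, with a wide range, and the step of a 1.0-fold lower number from compound 3 to compound 4 (0.02 log units; within the scatter) is estimated to stay within the scatter. Compound 4 is expected to give about 11000 nM, between 3000 nM and 40000 nM.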

Compound 4, half-maximal inhibitory concentration: 24600 nM
Beside the measured number, compound 4's estimate is 2.2-fold (0.35 log units) below it; the range from low to high includes it.
By their numbers in this assay, from the lowest: compounds 3, 1 and 4 (each within the scatter of the next, the first and the last beyond it). At a limit, above all of these: compound 2.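

The chain bound to the oxygen now has a measured step of its own: in this assay there is a 2.2-fold higher number from compound 3 to compound 4 (0.33 log units; beyond the scatter). What sits on this chain therefore affects the number, though only modestly, and 4-bromophenyl gives no gain over 2-hydroxyethyl. The position also accepts this larger group with an aromatic ring, as compound 4 still gives a measured number, 24600 nM.

The change swaps the hydroxyl-bearing chain for a brominated ring in one move, so it remains open which part accounts for the step, and a plain benzyl group, or a longer chain ending in an amine or a carboxylic acid, would help to separate these. Compounds much weaker than compound 4 may also be hard to size in this read-out: the limit of > 30000 nM in this assay, at which 1 of the 4 values shown sits.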